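A few compounds are considered here, and "the series" means these few. Any claim that something is new, unique, unknown or untested is made for them only; others in the source may bear on it.

Measured compounds in an assay on isolated protein for displacement of a labelled ligand from E3 ubiquitin-protein ligase Mdm2 (Homo sapiens), read by fluorescence polarization, with a stated time of 15 min; a lower number here means a stronger inhibitor, a higher number a weaker inhibitor:
compound 1 `O=C1CCC(N2Cc3c(CCCCCNC(=O)[C@@H]4NC5(CCCCC5)[C@@]5(C(=O)Nc6cc(Cl)ccc65)[C@H]4c4ccccc4)cccc3C2=O)C(=O)N1`; in this assay compound 1 gives > 20000 nM, which is a limit of the assay and not a number.
compound 2 `O=C1CCC(N2Cc3c(CCCCCNC(=O)[C@@H]4NC5(CCCCC5)[C@@]5(C(=O)Nc6ccccc65)[C@H]4c4ccccc4)cccc3C2=O)C(=O)N1`; in this assay compound 2 gives > 20000 nM, likewise a limit and not a number.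

Compound 1 therefore stands only at a limit in this assay, and the other value shown sits at the same limit (the limit of > 20000 nM in this assay, at which 2 of the 2 values shown sit). Within the data shown here, the single measured step, a step that the two limits leave unreadable from compound 1 to compound 2, runs between two limits and its size cannot be read.

Compound 3 `O=C1CCC(N2Cc3c(CCCCCNC(=O)[C@@H]4NC5(CCCCC5)[C@@]5(C(=O)Nc6cc(Cl)ccc65)[C@H]4c4cccc(Cl)c4F)cccc3C2=O)C(=O)N1` differs from compound 1 by 3-chloro-2-fluorophenyl in place of phenyl on a saturated ring carbon. Among the measured compounds shown here, no measured step bears on this change: the step from compound 1 to compound 2 concerns a chloro on an aromatic carbon of the core, not the group entering here, and has no readable size anyway. The expectation for compound 3 rests on nothing firmer than compound 1 sitting at the limit, so the value could remain at the limit or move in either direction.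

Compound 3 is estimated to give 8000 nM in this assay, within a range of 500 nM to 20000 nM. This estimate means an expected step of an at least 2.5-fold lower number from compound 1 to compound 3 (0.39 log units; beyond the scatter).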

Compound 3, half-maximal inhibitory concentration: 67.5 nM
Compound 3: the middle estimate sits 120-fold (2.07 log units) above what was measured; the whole stated range lies above it.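

In this assay, among these compounds, the saturated ring carbon two ring bonds from the ring nitrogen proves responsive: 3-chloro-2-fluorophenyl in place of phenyl there gives an at least 290-fold lower number from compound 1 to compound 3 (2.47 log units; beyond the scatter), and compound 3 gives 67.5 nM, the only value shown that is a number and not a limit. The earlier pair could show no such thing, since the step between compound 1 and compound 2, which removes the chloro from an aromatic carbon of the core, cannot be read. Within the three compounds shown, both with plain phenyl at this carbon sit at a limit, and the one with 3-chloro-2-fluorophenyl does not: the limit of > 20000 nM in this assay, at which 2 of the 3 values shown sit.

As far as these compounds go, how the step divides between the chlorine and the fluorine of the entering group stays open, and a 3-chlorophenyl or a 2-fluorophenyl on the same carbon would separate the two. Also open, from the compounds shown here alone, are whether the chloro on the core counts once 3-chloro-2-fluorophenyl is in place, and how a shorter or longer chain in place of the five-carbon chain would read on the compound 3 scaffold.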